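The source may report more compounds than this note shows. Statements on the series, on what has been measured and on what is new or still open speak of the compounds shown alone.

Measured so far:
compound 1 `COc1ccc2cc([C@H](C)c3nnc(SCc4ccccc4)n3-c3ccc(Cl)cc3)ccc2c1` — 35800 nM
compound 2 `COc1ccc2cc([C@H](C)c3nnc(SCc4c(C)cc(C)cc4C)n3-c3ccc(F)cc3)ccc2c1` — 10200 nM

In a functional assay on DU-145 cells (Homo sapiens) for cytotoxicity, read by MTT assay (on this read-out lower numbers stand for stronger inhibition and higher numbers for weaker inhibition), compound 1 stands at the highest of the two numbers, while compound 2 sits at a lower number, a gap beyond the usual scatter. Compound 3 `COc1ccc(CSc2nnc([C@@H](C)c3ccc4cc(OC)ccc4c3)n2-c2ccc(Cl)cc2)cc1` differs from compound 1 in one place: methoxy in place of hydrogen on an aromatic carbon. Within the data shown here, no measured pair here shows this exact change, so the step can only be guessed; a small improvement, near the edge of the scatter, seems plausible. The step from compound 1 to compound 3 is expected to be a 1.8-fold lower number from compound 1 to compound 3 (0.25 log units; within the scatter). Compound 3 is therefore estimated at 20000 nM, within a range from 7000 nM to 60000 nM.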

Compound 3, half-maximal inhibitory concentration: 72600 nM
Estimate against measurement, compound 3: 3.6-fold (0.56 log units) below; the whole stated range lies below it.
By their numbers in this assay, from the lowest: compound 2; then compound 1; then compound 3.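

In this assay, changing benzylsulfanyl to (4-methoxybenzyl)sulfanyl gives a 2.0-fold higher number from compound 1 to compound 3 (0.31 log units; beyond the scatter), a modest step just beyond the scatter. Among these compounds, this is the first direct reading of this position, and in this single pair the added methoxy goes with weaker inhibition, not stronger. No measured property is available to explain the step. On these data alone, whether an amine or a carboxylic acid at this same place would shift the number, and in which direction, stays open, as does how methoxy behaves elsewhere on this ring.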